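The source may report more compounds than this note shows. Statements on the series, on what has been measured and on what is new or still open speak of the compounds shown alone.

Compound 3 `O=C(COc1ccc(C(=O)/C=C/c2cccc([N+](=O)[O-])c2)cc1)N[C@H]1CCOC1=O` stands weakest of the three measured compounds in a functional assay on PC-3 cells (Homo sapiens) for antiproliferative activity, read by MTT assay, with a stated time of 72 h (on this read-out higher numbers stand for weaker inhibition and lower numbers for stronger inhibition), where compound 3 gives 56300 nM, while compound 1 `O=C(COc1ccc(C(=O)/C=C/c2ccc(F)cc2)cc1)N[C@H]1CCOC1=O` gives 15600 nM and compound 2 `O=C(COc1ccc(C(=O)/C=C/c2cccc(Br)c2)cc1)N[C@H]1CCOC1=O` gives 7890 nM. Compound 4 `O=C(COc1ccc(C(=O)/C=C/c2ccccc2Br)cc1)N[C@H]1CCOC1=O` differs from compound 3 by 2-bromophenyl in place of 3-nitrophenyl on a double-bonded chain carbon bound to a double-bonded chain carbon. Going by the values given here, two measured steps bear on this change. The step of a 7.1-fold higher number from compound 2 to compound 3 (0.85 log units; beyond the scatter) shows nitro in place of bromo raising the number; read in reverse, bromo in place of nitro should lower it. The step of a 3.6-fold higher number from compound 1 to compound 3 (0.56 log units; beyond the scatter) points the same way for losing the 3-nitrophenyl. Compound 2 carries 3-bromophenyl whereas compound 4 carries 2-bromophenyl, so a full reversal is not assured. Compound 4 is therefore expected to move by a 4.7-fold lower number from compound 3 to compound 4 (0.67 log units; beyond the scatter) in this assay. The estimated value of compound 4 is 12000 nM, between 4500 nM and 35000 nM.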

Compound 4, half-maximal inhibitory concentration: 3260 nM
The estimate for compound 4 lay 3.7-fold (0.57 log units) above the measured number, outside the stated range (below it).
By their numbers in this assay, from the lowest: compound 4; then compounds 2 and 1 (each within the scatter of the next); then compound 3.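

In this assay the change to 2-bromophenyl gives the largest step seen at this position (a 17-fold lower number from compound 3 to compound 4 (1.24 log units; beyond the scatter)). Moving the bromine alone also counts, a point the earlier compounds could not show: 2-bromophenyl in place of 3-bromophenyl gives a step beyond the scatter (a 2.4-fold lower number from compound 2 to compound 4 (0.38 log units; beyond the scatter)), and 2-bromophenyl also improves on 4-fluorophenyl (a 4.8-fold lower number from compound 1 to compound 4 (0.68 log units; beyond the scatter)). Nothing available accounts for these differences. The compounds shown leave open whether chloro, methoxy or an amine in place of the bromo would keep this activity.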